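Vero cell cytotoxicity: three measured analogues and one expected

A few compounds are considered here, and "the series" means these few. Any claim that something is new, unique, unknown or untested is made for them only; others in the source may bear on it.

Compound 1, `Cc1cccc(COc2ccc3c(c2)[C@@H](O)CN(C)C3)c1`: in an ADME assay on Vero cells (Chlorocebus sabaeus) for cytotoxicity, read by sulforhodamine B assay, with a stated time of 72 h (a higher number here means a weaker inhibitor, a lower number a stronger inhibitor), compound 1 gives > 50000 nM, a limit of the assay rather than a number.
Compound 2, `Cc1ccccc1COc1ccc2c(c1)[C@@H](O)CN(C)C2`: compound 2 gives > 100000 nM, also a limit.
Compound 3, `CN1Cc2ccc(OCCC3CCCCC3)cc2[C@@H](O)C1`: compound 3 gives > 50000 nM, again a limit.

Compound 3 thus stands at a limit, as do the other two values shown: the limit of > 50000 nM in this assay, at which 2 of the 3 values shown sit, and (the limit of > 100000 nM in this assay, at which 1 of the 3 values shown sits). None of the three steps between measured compounds can be sized: a step that the two limits leave unreadable from compound 1 to compound 2, a step that the two limits leave unreadable from compound 1 to compound 3 and a step that the two limits leave unreadable from compound 2 to compound 3 are all unreadable. On both sides of each of these steps the value is a limit.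

Compound 4, `CN1Cc2ccc(OCC3CCNCC3)cc2[C@@H](O)C1`, differs from compound 3 in one place: piperidin-4-yl in place of cyclohexylmethyl on a saturated chain carbon bound to an oxygen on an aromatic ring. Going by the values given here, no measured step bears directly on this change, and the three unreadable steps give no size to carry over. Compound 4 is therefore expected to remain at a limit in this assay, with a step that the limit leaves unreadable from compound 3 to compound 4 expected to be no step beyond the scatter. The estimate for compound 4 is 80000 nM, between 30000 nM and 200000 nM.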

Compound 4, half-maximal inhibitory concentration: > 100000 nM
Compound 4: only a limit was reported (the forecaster's own chance of this, stated with the estimate: 85%); at least 1.2-fold (0.09 log units) between middle value and limit.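

Compound 4, like compound 1, compound 2 and compound 3, gives only a limit in this assay, and none of the steps from those three to compound 4 can be read. The compounds shown leave open whether any of these groups on the shared core gives a half-maximal inhibitory concentration that is a number rather than a limit.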